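Replacing 3,4-difluorophenyl with 3-bromophenyl in compound 2

The source may hold more compounds than are shown below. What is called first, only, known or untested is meant among the compounds shown, and "the series" means these compounds.

compound 1 `Fc1ccc(/C=N/Nc2nc(-c3cc(C(F)(F)F)cc(C(F)(F)F)c3)cs2)cc1F` gives 16700 nM
compound 2 `Fc1ccc(/C=N/Nc2nc(-c3ccc(F)c(F)c3)cs2)cc1F` gives 26600 nM
compound 3 `COc1cc(/C=N/Nc2nc(-c3ccccc3)cs2)c(Br)c(Br)c1OC` gives 33600 nM

All three numbers come from a functional assay on HepG2 cells (Homo sapiens) for inhibition, read by MTT assay, with a stated time of 48 h; a lower number here means a stronger inhibitor, a higher number a weaker inhibitor. Compound 2 gives 26600 nM, the middle one of the three, and its gaps to compound 1 and to compound 3 both lie within the usual scatter of repeated measurements. Such gaps cannot be read as real differences.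

Compound 4 `Fc1ccc(/C=N/Nc2nc(-c3cccc(Br)c3)cs2)cc1F` has not yet been measured. It is compound 2 with 3-bromophenyl in place of 3,4-difluorophenyl on an aromatic carbon.

Among the measured compounds shown here, no pair of measured compounds differs in just one place, so no measured step shows what such a swap does. The expectation rests only on the narrow spread of the values, with compound 1 at 16700 nM and compound 3 at 33600 nM. The expected change in this assay is no more than the scatter, an estimated 1.2-fold lower number from compound 2 to compound 4 (0.08 log units; within the scatter). The estimate for compound 4 is 22000 nM, with an expected range of 9000 nM to 50000 nM.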

Compound 4, half-maximal inhibitory concentration: 16700 nM
Estimate against measurement, compound 4: 1.3-fold (0.12 log units) above; measured number inside the range.
By their numbers in this assay, from the lowest: compounds 1, 4, 2 and 3 (each within the scatter of the next).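

Among the compounds shown here, this is the first measured step at this position, the aromatic carbon of the five-membered ring next to the ring nitrogen: in this assay, putting 3-bromophenyl in place of 3,4-difluorophenyl gives a 1.6-fold lower number from compound 2 to compound 4 (0.20 log units; within the scatter). The swap of two fluorines for one bromine on the six-membered aromatic ring therefore produces no difference that can be told from repeated-measurement scatter, so this position accepts the change with no readable effect on the number. Nothing measured here explains this outcome or links it to any property of either group.

Going by these compounds, whether a different kind of substituent on this ring, such as an amine or a carboxylic acid, would move the number beyond the scatter remains open. So does whether the bromine would give the same result elsewhere on the ring.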